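From an aromatic amide to a saturated ring

The source may report more compounds than this note shows. Statements on the series, on what has been measured and on what is new or still open speak of the compounds shown alone.

Compound 3 `Cc1cccc(C(=O)N2CCc3nc(C#Cc4ccccc4)sc3C2)n1` in an assay on HEK293 cells for negative allosteric modulation of metabotropic glutamate receptor 5 (Homo sapiens), read by FLIPR, with a stated time of 1 h (on this read-out lower numbers stand for stronger inhibition and higher numbers for weaker inhibition), gives > 10000 nM, which is a limit of the assay rather than a number. Compound 1 `O=C(C1CCCC1)N1CCc2nc(C#Cc3ccccc3)sc2C1` gives > 10000 nM, again a limit. Compound 2 `CC1CCC(C(=O)N2CCc3nc(C#Cc4ccccc4)sc3C2)CC1` gives > 10000 nM, also a limit. Because all three sit at the limit of > 10000 nM in this assay, at which 3 of the 3 values shown sit, the steps a step that the two limits leave unreadable from compound 1 to compound 2, a step that the two limits leave unreadable from compound 1 to compound 3 and a step that the two limits leave unreadable from compound 2 to compound 3 cannot be sized. Compound 4 `O=C(N1CCCCC1)N1CCc2nc(C#Cc3ccccc3)sc2C1` differs from compound 3 by piperidin-1-yl in place of 6-methylpyridin-2-yl on a carbonyl carbon. For the measured compounds named here, no measured step bears on this change with a readable size, so no direction beyond the scatter can be expected in this assay. Compound 4 is therefore expected to give 15000 nM, with a range from 4000 nM to 60000 nM, most likely again only a limit. The step that the limit leaves unreadable from compound 3 to compound 4 is thus estimated to be close to none.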

Compound 4, half-maximal inhibitory concentration: > 10000 nM
Compound 4 ended at the assay's limit; the forecaster's own chance of this, stated with the estimate: 80%; the middle value does not contradict the limit.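

Compound 4 gives only a limit, as do compound 1, compound 2 and compound 3, so none of the steps among them can be read: the limit of > 10000 nM in this assay, at which 4 of the 4 values shown sit. Which group on the carbonyl carbon, if any, would give a readable value in this assay stays open.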